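Phenyl for Methyl on the Piperazine Nitrogen of a Benzothiazole Amide

The compounds below may be only part of what the source reports. "The series", "measured", "known", "first", "only" and "open" are said of these compounds alone.

Measured compounds:
- compound 1, `O=C(c1nc2cc(Cl)ccc2s1)N1CCN(c2ccccc2)CC1`, 41.2%
- compound 2, `CN1CCN(C(=O)c2nc3ccccc3s2)CC1`, 52.1%

Two compounds have been run in an ADME assay on RAW264.7 cells (Mus musculus) for cytotoxicity, read by MTT assay, with a stated time of 72 h, tested at 50 ug/mL; on this read-out higher numbers stand for more inhibition at the one concentration tested (going by the name of the read-out) and lower numbers for less inhibition. Compound 1 gives 41.2% in this assay, while compound 2 gives 52.1%, the higher of the two numbers, a gap beyond the scatter. Compound 3, `O=C(c1nc2ccccc2s1)N1CCN(c2ccccc2)CC1`, is still to be measured. It differs from compound 2 in one place: phenyl in place of methyl on an amine nitrogen in a ring. Going by the values given here, compound 1 also carries a phenyl on the ring nitrogen, but with a chlorine on the core, so no direct step from a measured pair isolates the change here. On the two numbers alone, compound 3 is expected to fall between them, and the step of a number 6.1 percentage points lower from compound 2 to compound 3 (within the scatter) is expected to be small, likely within the scatter. Compound 3 is estimated at 46%, with a range from 32% to 60%.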

Compound 3, a percentage reported as inhibition, at one concentration (the size of the read-out at that concentration, not a potency): 67.2%
The estimate for compound 3 lay 21.2 percentage points below the measured number, outside the stated range (above it).
By their numbers in this assay, from the lowest: compound 1; then compound 2; then compound 3.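

Phenyl in place of methyl on the amine nitrogen in a ring gives a number 15.1 percentage points higher from compound 2 to compound 3 (beyond the scatter) in this assay on the unchlorinated core, so this position takes the phenyl with more inhibition rather than less. With that phenyl kept, hydrogen in place of chloro on an aromatic carbon gives a number 26 percentage points higher from compound 1 to compound 3 (beyond the scatter) in this assay as well, which shows that the read-out also moves with a change on the core and not only with the group on the nitrogen. Nothing available here explains either step.

As far as these compounds go, whether the aromatic ring itself matters stays open, as a cyclohexyl or benzyl group on the same nitrogen would be needed to tell. From the compounds shown here alone, it is also open how a bare hydrogen on that nitrogen would read, or whether chloro on the core acts the same way when methyl sits on the nitrogen.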